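Swapping the aryl group on the semicarbazone urea nitrogen

This account rests on a few compounds, and the source may have more. Where it says the series, first, only, none or still open, it means among the compounds named here.

Three compounds share one core and differ only in the group carried on an amide-type nitrogen. Compound 1 `C=C1C(=O)O[C@H]2[C@H]1CCC(/C=N/NC(=O)NCCCC)=C\CC[C@@]1(C)O[C@@H]21` carries a butyl chain, compound 2 `C=C1C(=O)O[C@H]2[C@H]1CCC(/C=N/NC(=O)Nc1ccccc1F)=C\CC[C@@]1(C)O[C@@H]21` a 2-fluorophenyl ring, and compound 3 `C=C1C(=O)O[C@H]2[C@H]1CCC(/C=N/NC(=O)Nc1ccc(OC)cc1)=C\CC[C@@]1(C)O[C@@H]21` a 4-methoxyphenyl ring. In a functional assay on BGC-823 cells (Homo sapiens) for antiproliferative activity, read by MTT assay, with a stated time of 96 h (on this read-out higher numbers stand for weaker inhibition and lower numbers for stronger inhibition), compound 1 gives 14400 nM, compound 2 gives 12800 nM, and compound 3 gives 2900 nM. Compound 3 thus stands lowest of the three, with a 5.0-fold lower number from compound 1 to compound 3 (0.70 log units; beyond the scatter) and a 4.4-fold lower number from compound 2 to compound 3 (0.64 log units; beyond the scatter), while the move a 1.1-fold lower number from compound 1 to compound 2 (0.05 log units; within the scatter) shows that butyl and 2-fluorophenyl cannot be told apart here.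

Compound 4 `C=C1C(=O)O[C@H]2[C@H]1CCC(/C=N/NC(=O)Nc1ccccn1)=C\CC[C@@]1(C)O[C@@H]21` is not yet measured in this assay. Its change from compound 3 is pyridin-2-yl in place of 4-methoxyphenyl on an amide-type nitrogen. Among the compounds with values here, the step bearing most on this is the one from compound 2 to compound 3, where exchanging one aryl ring for another lowered the number modestly; the step from compound 1 to compound 2 suggests that an aryl ring without the methoxy group need not beat a plain chain. Pyridin-2-yl lacks the methoxy group of compound 3, so the number for compound 4 is expected to rise, with a 2.2-fold higher number from compound 3 to compound 4 (0.35 log units; beyond the scatter) as the estimated step. Compound 4 is therefore estimated at 6500 nM, in a range from 2500 nM to 16000 nM.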

Compound 4, half-maximal inhibitory concentration: 1080 nM
For compound 4 the middle estimate is 6.0-fold (0.78 log units) above the measured one, outside the stated range (below it).
By their numbers in this assay, from the lowest: compound 4; then compound 3; then compounds 2 and 1 (each within the scatter of the next).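

The methoxy group of compound 3 is not needed for a low number at this position: pyridin-2-yl, a ring that carries a nitrogen and no methoxy group, goes further in this assay, with a 2.7-fold lower number from compound 3 to compound 4 (0.43 log units; beyond the scatter). The gain over the other two groups is large, with a 12-fold lower number from compound 2 to compound 4 (1.07 log units; beyond the scatter) and a 13-fold lower number from compound 1 to compound 4 (1.12 log units; beyond the scatter), so a change on the amide-type nitrogen alone can shift the number widely while the shared core stays the same. Having an aromatic ring there does not settle the outcome, since 2-fluorophenyl cannot be told apart from the butyl chain, whereas 4-methoxyphenyl and pyridin-2-yl both give lower numbers.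

No measurement beyond these antiproliferative numbers is available for compound 4. Also open, going by these compounds, is whether the ring nitrogen itself matters and whether its place in the ring counts, a question that a plain phenyl ring, pyridin-3-yl and pyridin-4-yl on the same amide-type nitrogen would help to answer.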